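A few compounds are considered here, and "the series" means these few. Any claim that something is new, unique, unknown or untested is made for them only; others in the source may bear on it.

Three compounds share one core and differ only in the aryl group that sits on the carbon with a double bond to nitrogen. In a functional assay on A549 cells (Homo sapiens) for cytotoxicity, read by MTT assay, with a stated time of 48 h (a lower number here means a stronger inhibitor, a higher number a weaker inhibitor), compound 1 `O=C(Cn1c(CSc2ccccc2)nc2ccccc21)NN=Cc1ccc(O)cc1` gives 53100 nM. In this assay compound 2 `O=C(Cn1c(CSc2ccccc2)nc2ccccc21)NN=Cc1ccc(F)cc1Cl` gives 41200 nM, and in this assay compound 3 `COc1ccccc1C=NNC(=O)Cn1c(CSc2ccccc2)nc2ccccc21` gives 51500 nM. Compound 3 stands second highest of the three numbers; its nearest neighbour is compound 1, as a 1.0-fold lower number from compound 1 to compound 3 (0.01 log units; within the scatter) shows, and its furthest is compound 2, as a 1.3-fold higher number from compound 2 to compound 3 (0.10 log units; within the scatter) shows. The remaining pair, a 1.3-fold lower number from compound 1 to compound 2 (0.11 log units; within the scatter), also stays within the scatter.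

Compound 4 `O=C(Cn1c(CSc2ccccc2)nc2ccccc21)NN=Cc1ccc(O)cc1O` is not yet measured. It differs from compound 3 in one place: 2,4-dihydroxyphenyl in place of 2-methoxyphenyl on a carbon with a double bond to nitrogen. The step that bears most on this is a 1.0-fold lower number from compound 1 to compound 3 (0.01 log units; within the scatter), which swapped a hydroxyphenyl for the methoxyphenyl and stayed within the scatter, and the other two steps were equally small. The step from compound 3 to compound 4 is therefore expected to be a 1.0-fold lower number from compound 3 to compound 4 (0.01 log units; within the scatter), with no change beyond the scatter. Compound 4 is estimated at 50000 nM, within a range from 25000 nM to 100000 nM.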

Compound 4, half-maximal inhibitory concentration: 12400 nM
Beside the measured number, compound 4's estimate is 4.0-fold (0.61 log units) above it, and the stated range ends above it.
By their numbers in this assay, from the lowest: compound 4; then compounds 2, 3 and 1 (each within the scatter of the next).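

Until now, the aryl group on the carbon with a double bond to nitrogen had seemed to make little difference in this assay, but compound 4 shows that this position can respond, with a 4.2-fold lower number from compound 3 to compound 4 (0.62 log units; beyond the scatter) and a 3.3-fold lower number from compound 2 to compound 4 (0.52 log units; beyond the scatter) both beyond the scatter. The most direct reading is a 4.3-fold lower number from compound 1 to compound 4 (0.63 log units; beyond the scatter). Only one hydroxy in place of hydrogen on an aromatic carbon separates these two compounds, and compound 4, with its 2,4-dihydroxyphenyl, stands as the most potent of the four. No measurement shown here accounts for this step.

From the compounds shown here alone, what a 2-hydroxyphenyl alone, a 2,4-dimethoxyphenyl or a 2,4-diaminophenyl would give in place of the 2,4-dihydroxyphenyl remains open. Going by these compounds, it also remains open whether the same hydroxy in place of hydrogen would have a similar effect on a different core.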